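From dimethylpiperazine to aminopiperidine: estimating tolerance

The source may hold more compounds than are shown below. What is called first, only, known or untested is meant among the compounds shown, and "the series" means these compounds.

Values in an ADME assay on CHO cells (Cricetulus griseus) for cytotoxicity, read by MTT assay (a higher number here means that more compound is tolerated, a lower number that less compound is tolerated), for three compounds
compound 1 `CN1CCN(c2nccc3nc(-c4ccc(F)c(F)c4)[nH]c23)CC1` gives 50000 nM
compound 2 `C[C@@H]1CN(c2nccc3[nH]c(-c4ccc(F)c(F)c4)nc23)C[C@H](C)N1` gives 6500 nM
compound 3 `C[C@@H]1CN(c2nccc3[nH]c(-c4ccc(F)c(F)c4)nc23)C[C@H](C)N1C` gives > 50000 nM (a limit of the assay, not a number)

Compound 2 holds the lowest number here (6500 nM), and compound 1 stands higher (50000 nM). Compound 4 `NC1CCN(c2nccc3[nH]c(-c4ccc(F)c(F)c4)nc23)CC1` has not yet been measured. It carries 4-aminopiperidin-1-yl in place of 3,5-dimethylpiperazin-1-yl on an aromatic carbon. Going by the values given here, the one measured step that bears on this change is methyl in place of hydrogen on an amine nitrogen in a ring (an at least 7.6-fold higher number from compound 2 to compound 3 (0.88 log units; beyond the scatter)), which lies beyond the scatter and ends on a limit (the limit of > 50000 nM in this assay, at which 1 of the 3 values shown sits). Compound 4 has no methyl on its free amine nitrogen, and neither does compound 2 (6500 nM), so no large rise is expected in this assay and any rise should be small. The estimated step stays small (a 1.5-fold higher number from compound 2 to compound 4 (0.19 log units; within the scatter)). For compound 4 the estimated value is 10000 nM, with an expected range from 3000 nM to 35000 nM in this estimate.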

Compound 4, half-maximal cytotoxic concentration: 8200 nM
Compound 4: middle estimate off by 1.2-fold (0.09 log units), on the high side, within the range that was stated.
By their numbers in this assay, from the lowest: compounds 2 and 4 (each within the scatter of the next); then compound 1.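

In this assay, placing 4-aminopiperidin-1-yl instead of 3,5-dimethylpiperazin-1-yl on this aromatic carbon gives a 1.3-fold higher number from compound 2 to compound 4 (0.10 log units; within the scatter), so the two groups cannot be told apart here. The earlier compounds shown here showed only an edit to the ring amine, an at least 7.6-fold higher number from compound 2 to compound 3 (0.88 log units; beyond the scatter), whereas this result shows that the whole ring can be exchanged, with one ring hetero atom in place of two and no defined stereocentres, without a step beyond the scatter. The data shown offer no explanation for why these two groups read alike.

As far as these compounds go, it remains open whether a methyl on the free amine of compound 4 would produce a step like the one seen with the piperazine. How a morpholine ring or an open-chain amine would read at this position is also unknown.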